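Replacing the cyclohexylcarbonyl with cyclohexylmethyl on the quinoline nitrogen

The compounds below may be only part of what the source reports. "The series", "measured", "known", "first", "only" and "open" are said of these compounds alone.

Measured compounds:
compound 1 `COc1ncc(-c2ccc3ncc(NC(=O)C4CCCCC4)c(OC)c3c2)cc1NS(=O)(=O)c1ccc(F)cc1F` 4610 nM
compound 2 `COc1ncc(-c2ccc3ncc(NCc4ccc(C(F)(F)F)cc4)c(OC)c3c2)cc1NS(=O)(=O)c1ccc(F)cc1F` 3220 nM
compound 3 `COc1ncc(-c2ccc3ncc(NCC4CCN(S(C)(=O)=O)CC4)c(OC)c3c2)cc1NS(=O)(=O)c1ccc(F)cc1F` 1360 nM

In a functional assay on HCT-116 cells (Homo sapiens) for antiproliferative activity, read by sulforhodamine B assay, with a stated time of 72 h (on this read-out lower numbers stand for stronger inhibition and higher numbers for weaker inhibition), compound 1 gives 4610 nM, the highest of the three numbers. Compound 2 sits nearest to it, with a 1.4-fold lower number from compound 1 to compound 2 (0.16 log units; within the scatter), and compound 3 furthest, with a 3.4-fold lower number from compound 1 to compound 3 (0.53 log units; beyond the scatter). Between the two amines themselves the gap is a 2.4-fold lower number from compound 2 to compound 3 (0.37 log units; beyond the scatter).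

Compound 4 `COc1ncc(-c2ccc3ncc(NCC4CCCCC4)c(OC)c3c2)cc1NS(=O)(=O)c1ccc(F)cc1F` has not been measured. It differs from compound 1 in one place: cyclohexylmethyl in place of cyclohexylcarbonyl on a nitrogen on an aromatic ring. Read one bond further out, the change is (cyclohexylcarbonyl)amino to (cyclohexylmethyl)amino, while the cyclohexyl ring itself is kept.

Among the compounds with values here, two measured steps bear on this change, as both also exchange the cyclohexylcarbonyl for a methylene-linked group on the same nitrogen: a 1.4-fold lower number from compound 1 to compound 2 (0.16 log units; within the scatter) and a 3.4-fold lower number from compound 1 to compound 3 (0.53 log units; beyond the scatter). Both ran to lower numbers, one within the scatter and one modestly beyond it. The step to compound 4 keeps the ring of compound 1 and changes only the link, so the expected step is a small lowering, a 2.0-fold lower number from compound 1 to compound 4 (0.30 log units; within the scatter), possibly not beyond the scatter. For compound 4 in this assay the estimate is 2300 nM, with a range from 1000 nM to 5500 nM.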

Compound 4, half-maximal inhibitory concentration: 13600 nM
The estimate for compound 4 lay 5.9-fold (0.77 log units) below the measured number, and the stated range ends below it.
By their numbers in this assay, from the lowest: compound 3; then compounds 2 and 1 (each within the scatter of the next); then compound 4.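

In this assay, the link on the nitrogen on an aromatic ring does not settle the outcome alone: with the cyclohexyl ring kept, exchanging the carbonyl for a methylene gives a 3.0-fold higher number from compound 1 to compound 4 (0.47 log units; beyond the scatter), so a methylene link does not by itself bring a lower number. With that link held constant, the group on the saturated chain carbon matters, since cyclohexyl gives a 4.2-fold higher number from compound 2 to compound 4 (0.63 log units; beyond the scatter) and a 10-fold higher number from compound 3 to compound 4 (1.00 log units; beyond the scatter). Compound 4 therefore has the weakest activity of the four, and the lower number of compound 3 relative to compound 1 goes with the 1-(methylsulfonyl)piperidin-4-yl group rather than with the link alone.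

No evidence is available on why the cyclohexylmethyl compound reads higher than its cyclohexylcarbonyl counterpart. The compounds shown leave open how a piperidin-4-ylmethyl group with an unsubstituted ring nitrogen, or a cyclohexylmethyl group carrying a carboxylic acid, would read here, and whether a carbonyl link bearing the 1-(methylsulfonyl)piperidin-4-yl group would differ from compound 3.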